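Trading Methoxyphenyl for Chloromethylphenyl: An Expectation

The source may report more compounds than this note shows. Statements on the series, on what has been measured and on what is new or still open speak of the compounds shown alone.

Compound 2 `CCC1=C(O)c2c(oc(-c3ccc(OC)cc3)cc2=O)C(CC)(CC)C1=O` gives 0.68 uM in a functional assay on KBVIN cells (Homo sapiens) for antiproliferative activity, read by sulforhodamine B assay, with a stated time of 3 days (on this read-out lower numbers stand for an effect already at smaller amounts and higher numbers for an effect only at larger amounts of compound), the lowest of the two numbers measured here. Compound 1 `CCCc1ccc(-c2cc(=O)c3c(o2)C(CC)(CC)C(=O)C(CC)=C3O)cc1` gives 12.2 uM. Among the measured compounds shown here, the single step joining them, an 18-fold lower number from compound 1 to compound 2 (1.25 log units; beyond the scatter), came with methoxy in place of propyl on an aromatic carbon. Compound 3 `CCC1=C(O)c2c(oc(-c3ccc(C)c(Cl)c3)cc2=O)C(CC)(CC)C1=O` carries 3-chloro-4-methylphenyl in place of 4-methoxyphenyl on an aromatic carbon. Because an 18-fold lower number from compound 1 to compound 2 (1.25 log units; beyond the scatter) arrived with the methoxy, and compound 3 loses that methoxy again, a higher number than compound 2 is expected, though the earlier step only partly matches this change. Compound 3 is estimated at 3 uM, within 1 uM to 10 uM, a step of a 4.4-fold higher number from compound 2 to compound 3 (0.64 log units; beyond the scatter).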

Compound 3, concentration for half-maximal effect: 2.15 uM
Beside the measured number, compound 3's estimate is 1.4-fold (0.14 log units) above it, within the range that was stated.
By their numbers in this assay, from the lowest: compound 2; then compound 3; then compound 1.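

This position does not depend on the methoxy alone. The 3-chloro-4-methylphenyl group, which has no hydrogen-bond acceptor, gives a 3.2-fold higher number from compound 2 to compound 3 (0.50 log units; beyond the scatter), a smaller loss than compound 1 showed, and it still gives a 5.7-fold lower number from compound 1 to compound 3 (0.75 log units; beyond the scatter). No evidence here explains why these aromatic groups differ.

Chlorine and methyl enter together, so their separate shares remain unknown, and a phenyl ring carrying only one of them would be needed to separate those shares. Going by these compounds, how an amine or a longer ether chain would behave at this position also remains open.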